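Ester to carbamate step on the shared core

The source may report more compounds than this note shows. Statements on the series, on what has been measured and on what is new or still open speak of the compounds shown alone.

Within the data shown here, three quinone-bearing analogues have numbers so far. In a functional assay on V79-379A cells (Cricetulus griseus) for cytotoxicity, read by MTT assay, in the presence of a further agent that is not named here (on this read-out higher numbers stand for weaker inhibition and lower numbers for stronger inhibition), compound 1 `COC1=CC(=O)c2c(c(CO)cn2C)C1=O` gives 220000 nM. Compound 2 `COC1=CC(=O)c2c(c(COC(=O)c3ccccc3F)c(C)n2C)C1=O` gives 164000 nM in this assay, the second highest of the three numbers; compound 1 lies nearest, within the scatter, while compound 3 `COC1=CC(=O)c2c(c(COc3ccccc3)c(C)n2C)C1=O` with 12000 nM in this assay lies furthest, beyond the scatter.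

Compound 4 `COC1=CC(=O)c2c(c(COC(N)=O)c(C)n2C)C1=O` has not been measured in this assay. It differs from compound 2 in one place: amino in place of 2-fluorophenyl on a carbonyl carbon. The 2-fluorophenyl leaves the carbonyl carbon and amino enters there; the oxygen next to the carbonyl group is kept.

Among the measured compounds shown here, no measured pair differs in a single place, so no step of this kind is known. For the measured compounds named here, the only compound without an aromatic group at this part of the structure, compound 1, sits within the scatter of compound 2. A step of modest size toward a higher number, or none beyond the scatter, is therefore expected for compound 4; the estimated step is a 1.5-fold higher number from compound 2 to compound 4 (0.18 log units; within the scatter). Compound 4 is expected to give about 250000 nM in this assay, likely between 80000 nM and 800000 nM.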

Compound 4, half-maximal inhibitory concentration: 25000 nM
Compound 4: middle estimate off by 10-fold (1.00 log units), on the high side, outside the stated range (below it).
By their numbers in this assay, from the lowest: compound 3; then compound 4; then compounds 2 and 1 (each within the scatter of the next).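

In this assay, among these compounds, amino in place of 2-fluorophenyl on a carbonyl carbon gives a 6.6-fold lower number from compound 2 to compound 4 (0.82 log units; beyond the scatter) and is the first single change read, showing that this position responds to the group on the carbonyl and that an aromatic ring there is not needed for a lower number. Carbamoyl in place of phenyl on an oxygen on a saturated carbon gives a 2.1-fold higher number from compound 3 to compound 4 (0.32 log units; beyond the scatter) and so leaves the phenyl ether, compound 3, with the lower number, though only by a modest step. Nothing at hand explains either step.

Open, as far as these compounds go, is whether the amide hydrogens of compound 4 matter, which a dimethylamino group on the same carbonyl carbon would test. Also open, from the compounds shown here alone, is how a plain phenyl or a methyl group on that carbon would stand against the 2-fluorophenyl of compound 2.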